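The compounds below may be only part of what the source reports. "The series", "measured", "known", "first", "only" and "open" are said of these compounds alone.

Of the compounds shown here, two sharing one core have been measured so far. In a functional assay on the whole organism (strain STD-dd) with Mus musculus as the target, in the maximal electroshock model, with a stated time of 2 h (on this read-out higher numbers stand for an effect only at larger amounts of compound and lower numbers for an effect already at smaller amounts), compound 1 `CCNS(=O)(=O)Cc1noc2ccc(F)cc12` gives 32 mg/kg, and compound 2 `CNS(=O)(=O)Cc1noc2ccc(Cl)cc12` gives 20 mg/kg. Compound 2 holds the lower of these two numbers, yet the gap to compound 1 lies within the scatter of repeated measurements, so the two cannot be told apart. Compound 3 `CCNS(=O)(=O)Cc1noc2ccc(Cl)cc12` has not yet been measured. It differs from compound 2 by methyl in place of hydrogen on a saturated chain carbon bound to a sulfonamide nitrogen. Within the data shown here, no pair of measured compounds shows what this change does, so nothing beyond the scatter is expected. Compound 3 is expected to give about 25 mg/kg, between 12 mg/kg and 50 mg/kg. The step of a 1.3-fold higher number from compound 2 to compound 3 (0.10 log units; within the scatter) that this estimate means is expected to stay within the scatter.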

Compound 3, dose for half-maximal effect: 21 mg/kg
Compound 3: the middle estimate sits 1.2-fold (0.08 log units) above what was measured, and the stated range covers the measured number.
By their numbers in this assay, from the lowest: compounds 2, 3 and 1 (each within the scatter of the next).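

In this assay the change from hydrogen to methyl on a saturated chain carbon bound to a sulfonamide nitrogen can now be read directly (a 1.1-fold higher number from compound 2 to compound 3 (0.02 log units; within the scatter)), and this step stays within the scatter. Among these compounds, the swap of fluoro for chloro on an aromatic carbon can also be read for the first time (a 1.5-fold lower number from compound 1 to compound 3 (0.18 log units; within the scatter)), and it too stays within the scatter. No measurement shown here accounts for these numbers.

On these data alone, whether a longer chain such as propyl at this place would give a step beyond the scatter remains open. The same holds for bromo on the aromatic carbon.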